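Compound 4: cyclohexylmethyl on the carbonyl carbon

A few compounds are considered here, and "the series" means these few. Any claim that something is new, unique, unknown or untested is made for them only; others in the source may bear on it.

For the measured compounds named here, in a functional assay on A549 cells (Homo sapiens) for cytotoxicity, read by MTT assay, with a stated time of 48 h (on this read-out lower numbers stand for stronger inhibition and higher numbers for weaker inhibition), compound 3 (`C=C1C(=O)O[C@H]2CC3=C[C@H](C/C(C)=C/[C@@H](OC(=O)/C=C/c4cccc(OC)c4)[C@H]12)OC3=O`) gives 6200 nM, the only actual number so far. Compound 1 (`C=C1C(=O)O[C@H]2CC3=C[C@H](C/C(C)=C/[C@@H](OC(=O)c4ccc(C(F)(F)F)cc4)[C@H]12)OC3=O`) reads > 10000 nM, which is a limit of the assay. Compound 2 (`C=C1C(=O)O[C@H]2CC3=C[C@H](C/C(C)=C/[C@@H](OC(=O)/C=C/c4ccc(N(C)C)cc4)[C@H]12)OC3=O`) reads > 10000 nM, again a limit. Only a small upward step from compound 3 would end at the limit of > 10000 nM in this assay, at which 2 of the 3 values shown sit.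

The next structure is compound 4 (`C=C1C(=O)O[C@H]2CC3=C[C@H](C/C(C)=C/[C@@H](OC(=O)CC4CCCCC4)[C@H]12)OC3=O`), and the change from compound 3 is cyclohexylmethyl in place of 2-(3-methoxyphenyl)ethenyl on a carbonyl carbon. Going by the values given here, no measured compound carries cyclohexylmethyl, so the evidence is indirect. Two steps end at the group that compound 4 gives up: an at least 1.6-fold lower number from compound 1 to compound 3 (0.20 log units; that floor lies within the scatter), and an at least 1.6-fold lower number from compound 2 to compound 3 (0.20 log units; that floor lies within the scatter). Neither gives a firm size, so no clear change in this assay is expected, with only a slight lean towards a higher number. The expected step is a 1.3-fold higher number from compound 3 to compound 4 (0.11 log units; within the scatter), which stays inside the usual scatter. For compound 4 the estimate is 8000 nM, with an expected range of 3000 nM to 20000 nM.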

Compound 4, half-maximal inhibitory concentration: 6900 nM
Estimate against measurement, compound 4: 1.2-fold (0.06 log units) above; the measured number falls inside the stated range.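

In this assay, replacing the 2-(3-methoxyphenyl)ethenyl on the carbonyl carbon with cyclohexylmethyl gives a 1.1-fold higher number from compound 3 to compound 4 (0.05 log units; within the scatter). This pair therefore shows that the number holds with the aromatic ring, the double bond and the hydrogen-bond acceptor of the leaving group all gone, and with a non-aromatic ring in their place. The other two steps give only floors, an at least 1.4-fold lower number from compound 2 to compound 4 (0.16 log units; that floor lies within the scatter) and an at least 1.4-fold lower number from compound 1 to compound 4 (0.16 log units; that floor lies within the scatter), as compound 1 and compound 2 each rest on a limit of the assay and not on a number: the limit of > 10000 nM in this assay, at which 2 of the 4 values shown sit.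

No two actual numbers in the series lie clearly apart, so no order of groups at this position can be read. As far as these compounds go, it remains open whether an amine, a carboxylic acid or a longer chain in place of cyclohexylmethyl would move the number beyond the scatter.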